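The compounds below may be only part of what the source reports. "The series", "measured", "known", "first", "only" and "open" are said of these compounds alone.

For the measured compounds named here, compound 1 `c1ccc(-c2cn3ccnc3c(-c3ccc4ncn(C5CCCCC5)c4c3)n2)cc1` stands highest of the three numbers measured so far; in a functional assay on SK-MEL-28 cells (Homo sapiens) for inhibition, read by sulforhodamine B assay, with a stated time of 48 h, tested at 10 uM (a higher number here means more inhibition at the concentration tested (going by the name of the read-out), a lower number less inhibition), compound 1 gives 18%. Compound 2 `O=Cc1ccc(-c2cn3ccnc3c(-c3ccc4ncn(C5CCCCC5)c4c3)n2)cc1` gives 7.54% in this assay, and compound 3 `Fc1ccc(-c2cn3ccnc3c(-c3ccc4ncn(C5CCCCC5)c4c3)n2)cc1` gives 2.67%. The move to compound 4 `Clc1ccc(-c2cn3ccnc3c(-c3ccc4ncn(C5CCCCC5)c4c3)n2)cc1` is chloro in place of hydrogen on an aromatic carbon. Going by the values given here, two measured steps bear on it, both starting from compound 1 and both placing a group on an aromatic carbon of the phenyl: a number 10.5 percentage points lower from compound 1 to compound 2 (beyond the scatter) and a number 15.3 percentage points lower from compound 1 to compound 3 (beyond the scatter). Both fell beyond the scatter, so for compound 4 a downward step of comparable size in this assay is expected, a number 11 percentage points lower from compound 1 to compound 4 (beyond the scatter). Compound 4 is therefore estimated at 7%, with a range from 0% to 18%.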

Compound 4, a percentage reported as inhibition, at one concentration (the size of the read-out at that concentration, not a potency): 12.1%
Compound 4: middle estimate off by 5.1 percentage points, on the low side; the measured number falls inside the stated range.
By their numbers in this assay, from the lowest: compounds 3, 2, 4 and 1 (each within the scatter of the next, the first and the last beyond it).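

Of the three groups placed on this phenyl carbon, only chloro leaves a step within the scatter in this assay (a number 5.9 percentage points lower from compound 1 to compound 4 (within the scatter)), so substitution here need not lower the number beyond the scatter. Chloro also cannot be separated from fluoro (a number 9.4 percentage points higher from compound 3 to compound 4 (within the scatter)) or formyl (a number 4.6 percentage points higher from compound 2 to compound 4 (within the scatter)), which gives the three groups no order among themselves. No measurement shown accounts for these numbers.

On these data alone, it remains open whether an amine or a carboxylic acid at this place would differ from hydrogen, and whether chloro elsewhere on the phenyl would match compound 4.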